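The compounds below may be only part of what the source reports. "The series", "measured", "known", "first", "only" and "open" are said of these compounds alone.

Measured so far in an ADME assay on MT4 cells (Homo sapiens) for cytotoxicity, read by MTT assay, with a stated time of 5 days; on this read-out lower numbers stand for higher toxicity in this test and higher numbers for lower toxicity in this test:
compound 1 `Cc1cc(/C=C/C#N)cc(C)c1Oc1cc(Nc2ccc(C#N)cc2)nc(NC2CC2)c1` gives 24800 nM
compound 2 `Cc1cc(/C=C/C#N)cc(C)c1Oc1cc(NCCN(C)C)nc(Nc2ccc(C#N)cc2)c1` gives 4270 nM

Of these two, compound 2 has the lower number and so stands as the more toxic in this test. Compound 3 `C=CCNc1cc(Oc2c(C)cc(/C=C/C#N)cc2C)cc(Nc2ccc(C#N)cc2)n1` has not yet been measured. It carries vinyl in place of (dimethylamino)methyl on a saturated chain carbon bound to a nitrogen on an aromatic ring. Among the measured compounds shown here, the one measured step that bears on this is a 5.8-fold lower number from compound 1 to compound 2 (0.76 log units; beyond the scatter) with 2-(dimethylamino)ethyl in place of cyclopropyl on a nitrogen on an aromatic ring. Since compound 3 lacks that 2-(dimethylamino)ethyl, as does compound 1 at 24800 nM, a step of similar size towards a higher number is expected in this assay. The expected step is a 3.7-fold higher number from compound 2 to compound 3 (0.57 log units; beyond the scatter). For compound 3 the estimated value is 16000 nM, with an expected range of 6500 nM to 38000 nM.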

Compound 3, half-maximal cytotoxic concentration: 82100 nM
Compound 3: the middle estimate sits 5.1-fold (0.71 log units) below what was measured, outside the stated range (above it).
By their numbers in this assay, from the lowest: compound 2; then compound 1; then compound 3.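

At this position, on a saturated chain carbon bound to a nitrogen on an aromatic ring, vinyl in place of (dimethylamino)methyl gives in this assay a 19-fold higher number from compound 2 to compound 3 (1.28 log units; beyond the scatter), so the cytotoxicity read-out responds strongly to this change in the side chain. Losing the 2-(dimethylamino)ethyl does not return the number to a single level, since allyl in place of cyclopropyl on a nitrogen on an aromatic ring gives a 3.3-fold higher number from compound 1 to compound 3 (0.52 log units; beyond the scatter). Among these three compounds, the two without the dimethylamino group therefore stand apart from each other as well as from compound 2.

As far as these compounds go, it remains open whether a saturated propyl chain would read like allyl. Equally open, from the compounds shown here alone, is whether a primary amine, a morpholine or a hydroxyl at the end of the ethyl chain would read like 2-(dimethylamino)ethyl.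

Nothing given here accounts for these differences.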